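Trifluoromethyl count on the benzamide side chain

A few compounds are considered here, and "the series" means these few. Any claim that something is new, unique, unknown or untested is made for them only; others in the source may bear on it.

Measured compounds:
compound 1, `O=C(Nc1ccc(-n2ccc3c(NC(=O)c4ccccc4)ncnc32)cc1)c1ccc(Cl)c(C(F)(F)F)c1`, 5500 nM in an ADME assay on HS27 cells (Homo sapiens) for antiproliferative activity, read by MTT assay, with a stated time of 24 h; a lower number here means a stronger inhibitor, a higher number a weaker inhibitor
compound 2, `O=C(Nc1ccc(-n2ccc3c(NC(=O)c4ccccc4)ncnc32)cc1)c1cc(C(F)(F)F)cc(C(F)(F)F)c1`, 6600 nM

The two measured compounds share one core and differ only in the substitution of the benzamide ring. In this assay, among the compounds with values here, compound 2 gives 6600 nM; the only comparison available is compound 1, and the gap between the two values lies within the usual scatter, so the two readings cannot be told apart.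

Compound 3, `O=C(Nc1ccc(-n2ccc3c(NC(=O)c4ccccc4)ncnc32)cc1)c1cccc(C(F)(F)F)c1`, is not yet measured. Relative to compound 2 the change is hydrogen in place of trifluoromethyl on an aromatic carbon. One trifluoromethyl remains on the ring; the other is removed.

Within the data shown here, no step between measured compounds is available for this kind of change, so there is nothing to lean on beyond the two values shown. Both lie close together despite different substitution of the same ring, which speaks for a small step. The expectation for the step from compound 2 to compound 3 is therefore none beyond the scatter, a 1.2-fold lower number from compound 2 to compound 3 (0.08 log units; within the scatter), with the direction left open.

Compound 3 is estimated at 5500 nM, in the range 2500 nM to 12000 nM.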

Compound 3, half-maximal inhibitory concentration: 5900 nM
Compound 3: the middle estimate sits 1.1-fold (0.03 log units) below what was measured, within the range that was stated.
By their numbers in this assay, from the lowest: compounds 1, 3 and 2 (each within the scatter of the next).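

In this assay, hydrogen in place of trifluoromethyl on an aromatic carbon can now be read as a direct step: a 1.1-fold lower number from compound 2 to compound 3 (0.05 log units; within the scatter). Hydrogen in place of chloro on an aromatic carbon can also be read directly, a 1.1-fold higher number from compound 1 to compound 3 (0.03 log units; within the scatter), so neither replacement separates compound 3 from its neighbour, and the three compounds cannot be told apart in this assay. Nothing measured here bears on why these readings coincide.

Only chloro, trifluoromethyl and hydrogen are shown at these places on the benzamide ring, so it remains open whether an amine, a carboxylic acid or a longer alkyl chain there would give a step beyond the scatter. Also open, going by these compounds, is whether a ring with hydrogen at both places would still read alongside these three compounds, and whether the same flat picture would hold for these replacements on a different core.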